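The source may report more compounds than this note shows. Statements on the series, on what has been measured and on what is new or still open speak of the compounds shown alone.

Measured so far in a functional assay on HeLa cells (Homo sapiens) for antiproliferative activity, read by MTT assay, with a stated time of 48 h; a lower number here means a stronger inhibitor, a higher number a weaker inhibitor:

- compound 1 `Oc1ccc2ccccc2c1C(Nc1nc2ccccc2s1)c1cn(-c2ccccc2)nc1-c1ccccc1`: 17300 nM
- compound 2 `Oc1ccc2ccccc2c1C(Nc1nc2ccccc2s1)c1cn(-c2ccccc2)nc1-c1ccc(I)cc1`: 6590 nM

Compound 2 holds the lower of these two numbers, 6590 nM, which makes it the stronger inhibitor of the pair. Compound 3 `Oc1ccc2ccccc2c1C(Nc1nc2ccc(Cl)cc2s1)c1cn(-c2ccccc2)nc1-c1ccc(I)cc1` keeps the structure of compound 2 with a single alteration: chloro in place of hydrogen on an aromatic carbon. This is chloro in place of hydrogen on an aromatic carbon, so the 1,3-benzothiazol-2-yl group becomes 6-chloro-1,3-benzothiazol-2-yl.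

Going by the values given here, only one measured step offers any guidance, namely a 2.6-fold lower number from compound 1 to compound 2 (0.42 log units; beyond the scatter). That step was modest and also replaced hydrogen on an aromatic carbon, but it introduced iodo rather than chloro, at a different place in the molecule. Among the compounds with values here, it is therefore a loose guide, and no measured step tests the new position directly. A small move towards a lower number in this assay seems most likely, though it may not clear the scatter.

The expected change is a 1.5-fold lower number from compound 2 to compound 3 (0.17 log units; within the scatter). For compound 3 the estimated value is 4500 nM, with an expected range from 1800 nM to 11000 nM.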

Compound 3, half-maximal inhibitory concentration: 12100 nM
Beside the measured number, compound 3's estimate is 2.7-fold (0.43 log units) below it; measured number outside the range, above it.
By their numbers in this assay, from the lowest: compounds 2, 3 and 1 (each within the scatter of the next, the first and the last beyond it).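

In this assay the 6-chloro-1,3-benzothiazol-2-yl group of compound 3 replaces the unsubstituted 1,3-benzothiazol-2-yl group of compound 2, giving a 1.8-fold higher number from compound 2 to compound 3 (0.26 log units; within the scatter) and therefore no change that can be told apart from ordinary repeat variation. The earlier step, a 2.6-fold lower number from compound 1 to compound 2 (0.42 log units; beyond the scatter) for iodo in place of hydrogen elsewhere in the molecule, did not test this part of the structure, whereas this result shows that a chloro group on this carbon, meta to a fused ring and para to a fused ring, produces no clear shift in this assay. Nothing shown here gives a measured property that would help interpret this result.

A single chloro group at one position cannot show whether a different group on this carbon, such as methoxy, an amine or a carboxylic acid, would move the number beyond the scatter. Going by these compounds, it also remains open whether chloro would behave the same way on the other carbons of this six-membered ring, or in a compound without the iodo group.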